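Replacing an amino group with an ester at the shared core

This account rests on a few compounds, and the source may have more. Where it says the series, first, only, none or still open, it means among the compounds named here.

Compound 3 `CCCCNc1nc(N2CC(=O)Nc3cc(OC)ccc32)c2ccccc2n1` carries a butylamino group on the shared core. In a functional assay on MCF7 cells (Homo sapiens) for inhibition, read by sulforhodamine B assay, with a stated time of 48 h (a higher number here means a weaker inhibitor of growth, a lower number a stronger inhibitor of growth), compound 3 gives 7.88 nM. Compound 1 `COc1ccc2c(c1)NC(=O)CN2c1nc(Nc2ccc(C#N)cc2)nc2ccccc12` carries 4-cyanophenylamino at the same position, and in this assay compound 1 gives 9.19 nM; the step of a 1.2-fold lower number from compound 1 to compound 3 (0.07 log units; within the scatter) shows that these two compounds sit within the scatter of each other. Compound 2 `COc1ccc2c(c1)NC(=O)CN2c1nc(N2CCCC2)nc2ccccc12` carries a pyrrolidine ring there, but in this assay compound 2 gives "not determined" (no result reported), so no number is available for it.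

Compound 4 `COc1ccc2c(c1)NC(=O)CN2c1nc(COC(C)=O)nc2ccccc12` differs from compound 3 in one place: acetoxymethyl in place of butylamino on an aromatic carbon. Going by the values given here, no measured step covers this kind of exchange; the single measured step swaps one amino substituent for another and changes little. The expectation for compound 4 in this assay therefore rests on weak ground, and the estimated step of a 1.9-fold higher number from compound 3 to compound 4 (0.28 log units; within the scatter) is a modest one. Compound 4 is expected to give about 15 nM in this assay, with a plausible range from 4 nM to 60 nM.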

Compound 4, concentration for 50% growth inhibition in the MCF7 assay: 33 nM
Compound 4: the middle estimate sits 2.2-fold (0.34 log units) below what was measured; the measured number falls inside the stated range.
By their numbers in the MCF7 assay, from the lowest: compounds 3 and 1 (each within the scatter of the next); then compound 4.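

Going by these compounds alone, at this position, on an aromatic carbon between two ring nitrogen atoms, the two amino groups read alike, but acetoxymethyl is the first exchange to move the number beyond the scatter. In the MCF7 assay there is a 4.2-fold higher number from compound 3 to compound 4 (0.62 log units; beyond the scatter) and a 3.6-fold higher number from compound 1 to compound 4 (0.56 log units; beyond the scatter), so compound 4 is a weaker inhibitor of growth than either amino compound. In a physicochemical assay for lipophilicity, read by HPLC, measured as octanol-water partition, tested at 1 mg/mL (a higher number here means a more lipophilic compound, a lower number a more polar compound), compound 3 gives 3.91 and compound 4 gives 2.7, so the same exchange also brings a number 1.21 log units lower from compound 3 to compound 4 (beyond the scatter).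

The compounds shown cannot separate the lost hydrogen-bond donor from this shift in partition coefficient, as both arrive in the same exchange. Going by these compounds, how hydroxymethyl or a longer chain such as pentyl on this aromatic carbon would read in the MCF7 assay remains open.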